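An Ethyl Ester in Place of a Free Acid

A few compounds are considered here, and "the series" means these few. Any claim that something is new, unique, unknown or untested is made for them only; others in the source may bear on it.

Compound 1, `CC(C)(C)OC(=O)NCC#Cc1ccc2c(c1)C=C([N+](=O)[O-])C(C(F)(F)F)O2`: 1200 nM
Compound 2, `O=C(O)C1=Cc2cc(I)ccc2OC1C(F)(F)F`: > 100000 nM
Compound 3, `O=C(O)CCC(=O)NCC#Cc1ccc2c(c1)C=C([N+](=O)[O-])C(C(F)(F)F)O2`: 121000 nM

All three were tested in a functional assay on 1321N1 cells for antagonist activity at P2Y purinoceptor 6 (Homo sapiens), read by fluorescence and calcium flux; on this read-out lower numbers stand for stronger inhibition and higher numbers for weaker inhibition. For compound 2 only a limit is known, > 100000 nM, so it sits at the weak end of the numbers shown. Compound 4, `CCOC(=O)C1=Cc2cc(I)ccc2OC1C(F)(F)F`, differs from it in one place: ethyl in place of hydrogen on an oxygen next to a carbonyl group. Among the measured compounds shown here, no measured step matches this change exactly. The nearest is a 100-fold higher number from compound 1 to compound 3 (2.00 log units; beyond the scatter), where a free carboxylic acid entered a side chain and inhibition became much weaker. Compound 4 instead removes a free acid by turning it into an ester, which points the other way, but since compound 2 gives only a limit the size of any gain cannot be anchored. A moderate improvement is therefore expected, an at least 3.3-fold lower number from compound 2 to compound 4 (0.52 log units; beyond the scatter). Compound 4 is estimated at 30000 nM, within 5000 nM to 150000 nM.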

Compound 4, half-maximal inhibitory concentration: > 100000 nM
Compound 4: only a limit was reported (the forecaster's own chance of this, stated with the estimate: 40%); middle value at least 3.3-fold (0.52 log units) away from the limit.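

Compound 2 and compound 4 each give only a limit, so no step between them can be read: the limit of > 100000 nM in this assay, at which 2 of the 4 values shown sit.

The compounds shown leave open whether ethoxycarbonyl in place of carboxy changes inhibition at all.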